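Trading a ring-bearing arm for a short chain

The compounds below may be only part of what the source reports. "The series", "measured", "known", "first", "only" and "open" are said of these compounds alone.

Within the data shown here, in a functional assay on MCF7 cells (Homo sapiens) for inhibition, read by MTT assay, with a stated time of 48 h (on this read-out higher numbers stand for weaker inhibition and lower numbers for stronger inhibition), compound 2 `CCOC(=O)C1=C(N/C=N/c2ccc([N+](=O)[O-])cc2)Nc2[nH]nc(C)c2C1c1ccc(N(C)C)cc1` gives 58600 nM, the highest of the two numbers measured so far, with compound 1 `CCOC(=O)C1=C(N/C=N/c2ccccn2)Nc2[nH]nc(C)c2C1c1ccc(N(C)C)cc1` nearest at 37300 nM. Among the measured compounds shown here, the single measured step, a 1.6-fold higher number from compound 1 to compound 2 (0.20 log units; within the scatter), stays within the scatter and so offers no direction. For the measured compounds named here, compound 3 `CCOC(=O)C1=C(NN=C(C#N)C#N)Nc2[nH]nc(C)c2C1c1ccc(N(C)C)cc1` differs from compound 2 by a group of 6 heavy atoms (3 carbon, 3 nitrogen; no ring) in place of a group of 11 heavy atoms (7 carbon, 2 nitrogen, 2 oxygen; one six-membered aromatic ring of carbon only), on an amine nitrogen, a change of a different kind that no measured step mirrors. With nothing pointing either way, the expected step is a 1.3-fold lower number from compound 2 to compound 3 (0.11 log units; within the scatter), which need not stand beyond the scatter. Compound 3 is therefore estimated at 45000 nM, within 12000 nM to 170000 nM.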

Compound 3, half-maximal inhibitory concentration: 12100 nM
For compound 3 the middle estimate is 3.7-fold (0.57 log units) above the measured one, and the stated range covers the measured number.
By their numbers in this assay, from the lowest: compound 3; then compounds 1 and 2 (each within the scatter of the next).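

On the amine nitrogen, replacing either ring-bearing arm with the ring-free group moves the number beyond the scatter in this assay, with a 4.8-fold lower number from compound 2 to compound 3 (0.69 log units; beyond the scatter) and a 3.1-fold lower number from compound 1 to compound 3 (0.49 log units; beyond the scatter). Both steps point towards stronger inhibition, so this position does respond to what it carries, which the swap between the two ring-bearing arms could not show. No measurement here explains the gain. Still open, going by these compounds, is whether losing the ring or gaining the nitrile groups matters more. A plain ethyl chain or a phenyl ring without a nitro group on this nitrogen would help separate the two.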